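The source may report more compounds than this note shows. Statements on the series, on what has been measured and on what is new or still open speak of the compounds shown alone.

Of the compounds shown here, three sharing one core have been measured in a functional assay for activation of Alpha-1A adrenergic receptor (Homo sapiens), read by calcium flux; a lower number here means that less compound is needed, a higher number that more compound is needed for the effect: compound 1 `Cc1cccnc1-c1ccccc1OCC1=NCCN1`, compound 2 `Cc1cccc(-c2ccccc2OCC2=NCCN2)n1` and compound 3 `c1ccc(-c2ccncn2)c(OCC2=NCCN2)c1`. In this assay compound 2 gives 126 nM. For compound 1 the assay reports only a limit, < 100000 nM. Compound 3 likewise reaches only a limit, < 100000 nM, so no number is known for it; it stands at the limit of < 100000 nM in this assay, at which 2 of the 3 values shown sit. Compound 4 `c1ccc(-c2nccs2)c(OCC2=NCCN2)c1` has not yet been measured; it differs from compound 3 by 1,3-thiazol-2-yl in place of pyrimidin-4-yl on an aromatic carbon. Within the data shown here, no measured pair in this set differs in a single place, so the step from compound 3 to compound 4 has no measured counterpart to lean on. Compound 2 shows that a number inside the measured range occurs in this series, while compound 1 and compound 3 show that two of the three members give only the limit. The step that the limit leaves unreadable from compound 3 to compound 4 is therefore expected to be of uncertain direction, with a fair chance that compound 4 again returns only a limit. Compound 4 is estimated at 20000 nM, in a range from 500 nM to 100000 nM.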

Compound 4, half-maximal effective concentration: 2.51 nM
The estimate for compound 4 lay 8000-fold (3.90 log units) above the measured number; the measured number lies below the stated range.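

Among these compounds, no step from compound 3 to compound 4 can be read in this assay, since compound 3 has only a limit there: the limit of < 100000 nM in this assay, at which 2 of the 4 values shown sit. The compounds shown leave open how large the change from pyrimidin-4-yl to 1,3-thiazol-2-yl is, and whether it would act alike on another compound of this series.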